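Swapping thiophene for furan in a trimethoxyphenyl triazolothiadiazine

The source may hold more compounds than are shown below. What is called first, only, known or untested is meant among the compounds shown, and "the series" means these compounds.

Of the compounds shown here, two from this series have been measured in a functional assay on HepG2 cells (Homo sapiens) for cytotoxicity, read by MTT assay, with a stated time of 48 h; a lower number here means a stronger inhibitor, a higher number a weaker inhibitor. Compound 2, `COc1cc(-c2nnc3n2NC(c2cccs2)C(C(=O)c2ccc(C)cc2)S3)cc(OC)c1OC`, gives 3700 nM and stands as the lower of the two numbers. Compound 1, `COc1cc(-c2nnc3n2NC(c2ccco2)C(C(=O)c2ccc(Cl)cc2)S3)cc(OC)c1OC`, carries a furan and a chlorophenyl carbonyl instead and gives 78600 nM; its gap from compound 2 lies beyond the scatter, but the two structures differ in two places at once, so the gap cannot be assigned to either change alone.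

Compound 3, `COc1cc(-c2nnc3n2NC(c2ccco2)C(C(=O)c2ccc(C)cc2)S3)cc(OC)c1OC`, keeps the methylphenyl carbonyl of compound 2 and changes only one thing: furan-2-yl in place of thiophen-2-yl on a saturated ring carbon. Within the data shown here, no measured pair isolates this swap. Among the measured compounds shown here, compound 3 is expected to lose some potency, with a step of a 2.2-fold higher number from compound 2 to compound 3 (0.33 log units; beyond the scatter), since the only furan-bearing compound here, compound 1, gives 78600 nM. The estimated value for compound 3 is therefore 8000 nM, within a range from 2500 nM to 30000 nM.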

Compound 3, half-maximal inhibitory concentration: 17400 nM
The estimate for compound 3 lay 2.2-fold (0.34 log units) below the measured number, and the stated range covers the measured number.
By their numbers in this assay, from the lowest: compound 2; then compound 3; then compound 1.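

In this assay, among these compounds, this pair isolates the ring swap for the first time: furan-2-yl in place of thiophen-2-yl on the saturated ring carbon, with the methylphenyl carbonyl held constant, gives (a 4.7-fold higher number from compound 2 to compound 3 (0.67 log units; beyond the scatter)). Compound 3 also isolates the other change, since methyl in place of chloro on the aromatic carbon, with the furan held constant, gives (a 4.5-fold lower number from compound 1 to compound 3 (0.65 log units; beyond the scatter)). The large gap between compound 1 and compound 2 can therefore be read as two single changes, each beyond the scatter, with thiophen-2-yl and methyl each going with the lower number.

Nothing here explains either step. Going by these compounds, it remains open whether the furan step holds alongside the chlorophenyl carbonyl, and how a plain phenyl ring or an amine on the saturated ring carbon would compare.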